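Piperazine amides of the shared core: Vero cytotoxicity notes

The source may report more compounds than this note shows. Statements on the series, on what has been measured and on what is new or still open speak of the compounds shown alone.

Measured compounds:
compound 1, `O=C(c1ccc(Cl)cc1)N1CCN(c2nc(=O)c3cc(C(F)(F)F)cc([N+](=O)[O-])c3s2)CC1`
compound 2, `CC(C)(C)C(=O)N1CCN(c2nc(=O)c3cc(C(F)(F)F)cc([N+](=O)[O-])c3s2)CC1`
compound 3, `O=C(c1ccccc1Cl)N1CCN(c2nc(=O)c3cc(C(F)(F)F)cc([N+](=O)[O-])c3s2)CC1`

In an ADME assay on Vero cells (Chlorocebus sabaeus) for cytotoxicity, read by MTT assay, with a stated time of 72 h (on this read-out lower numbers stand for higher toxicity in this test and higher numbers for lower toxicity in this test), compound 1 gives > 125000 nM, which is a limit of the assay and not a number. Compound 2 gives > 125000 nM, likewise a limit. Compound 3 gives > 125000 nM, again a limit. All three values therefore sit at the limit of > 125000 nM in this assay, at which 3 of the 3 values shown sit, so the steps a step that the two limits leave unreadable from compound 1 to compound 2, a step that the two limits leave unreadable from compound 1 to compound 3 and a step that the two limits leave unreadable from compound 2 to compound 3 have no readable size, and compound 1 stands at the limit with nothing to set it apart from compound 2 or compound 3.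

Compound 4 is `CCC(C)C(=O)N1CCN(c2nc(=O)c3cc(C(F)(F)F)cc([N+](=O)[O-])c3s2)CC1`; against compound 1 the change is sec-butyl in place of 4-chlorophenyl on a carbonyl carbon. Going by the values given here, no measured step bears a readable size on this change; the nearest comparison, the branched alkyl of compound 2, also stays at the limit. Compound 4 is therefore expected to remain at the limit as well, with the step that the limit leaves unreadable from compound 1 to compound 4 expected to show no change beyond the scatter. The estimate for compound 4 is 150000 nM, expected to fall between 60000 nM and 400000 nM.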

Compound 4, half-maximal cytotoxic concentration: > 125000 nM
Compound 4: no number, only a limit; the forecaster's own chance of this, stated with the estimate: 80%; the middle value is on the limit's open side.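

In this assay compound 4 gives > 125000 nM, a limit and not a number. Its steps to compound 1, compound 2 and compound 3 cannot be read: the limit of > 125000 nM in this assay, at which 4 of the 4 values shown sit.

The compounds shown leave open whether any group on the carbonyl carbon sets these four compounds apart in this assay.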